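A chloro in place of a methyl on compound 1

A few compounds are considered here, and "the series" means these few. Any claim that something is new, unique, unknown or untested is made for them only; others in the source may bear on it.

In an ADME assay for permeability, using PAMPA, at pH 7.4 (on this read-out higher numbers stand for higher permeability and lower numbers for lower permeability), compound 1 `Cc1cc(NC(=O)Nc2ccc(C)c(Cl)c2)c2ccccc2n1` gives 262 10^-6 cm/s and stands lower of the two measured compounds, with compound 2 `Cc1cc(NC(=O)Nc2ccccc2OC(F)(F)F)c2ccccc2n1` at 1110 10^-6 cm/s above it, a gap beyond the scatter. Compound 3 `Cc1cc(NC(=O)Nc2ccc(Cl)c(Cl)c2)c2ccccc2n1` differs from compound 1 in one place: chloro in place of methyl on an aromatic carbon. Among the measured compounds shown here, no measured pair shows this change, so in this assay no step beyond the scatter is expected, in either direction. The expected 1.0-fold lower number from compound 1 to compound 3 (0.00 log units; within the scatter) stays small on that reading. For compound 3 the estimated value is 260 10^-6 cm/s with an expected range from 110 10^-6 cm/s to 620 10^-6 cm/s in this assay.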

Compound 3, apparent permeability: 197 10^-6 cm/s
Estimate against measurement, compound 3: 1.3-fold (0.12 log units) above; low and high end bracket the measured number.
By their numbers in this assay, from the lowest: compounds 3 and 1 (each within the scatter of the next); then compound 2.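

In this assay chloro in place of methyl on this aromatic carbon, para to a large group and ortho to a chloro group, gives a 1.3-fold lower number from compound 1 to compound 3 (0.12 log units; within the scatter) and so no step beyond the scatter. Among the compounds shown here, this is the first measured pair for this change, and at this position the two groups read alike. Nothing measured here offers an explanation for this result. As far as these compounds go, what a methoxy group or an amine at this position would give stays open. So does whether the same change would read alike elsewhere on the shared core.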